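Methyl for bromo on the aryl ring of the aldehyde series

This account rests on a few compounds, and the source may have more. Where it says the series, first, only, none or still open, it means among the compounds named here.

For the measured compounds named here, compound 3 `O=Cc1c(-c2ccc(Br)cc2)nc2sc(Cc3ccc(Cl)cc3)nn12` gives the lowest of the two numbers so far in a functional assay on L1210 cells (Mus musculus) for cytotoxicity, with a stated time of 48 h; a higher number here means a weaker inhibitor, a lower number a stronger inhibitor: compound 3 gives 4600 nM. Its nearest neighbour is compound 2 `O=Cc1c(-c2ccc(F)cc2)nc2sc(Cc3ccc(Cl)cc3)nn12`, which in this assay gives 20000 nM. Going by the values given here, the one step measured so far, a 4.3-fold lower number from compound 2 to compound 3 (0.64 log units; beyond the scatter), is the only direct evidence on what a change at this aromatic carbon does. Compound 1 `Cc1ccc(-c2cn3nc(Cc4ccc(Cl)cc4)sc3n2)cc1` lacks the carbonyl of the shared core and carries methyl at the same place; compound 1 reaches only the limit of this assay, > 250000 nM, which is a limit and not a number (the limit of > 250000 nM in this assay, at which 1 of the 3 values shown sits).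

Compound 4 `Cc1ccc(-c2nc3sc(Cc4ccc(Cl)cc4)nn3c2C=O)cc1` is not yet measured. It differs from compound 3 by methyl in place of bromo on an aromatic carbon. Among the compounds with values here, no measured pair shows methyl in place of bromo directly; the fluoro-to-bromo step is the only comparison at this carbon, and it was modest in size. Compound 1 does not bear on it, as it also lacks the carbonyl. A step of similar size, or none beyond the scatter, is expected here, towards a somewhat higher number. Compound 4 is therefore estimated at 8000 nM in this assay, within 2500 nM to 30000 nM, which means an expected step of a 1.7-fold higher number from compound 3 to compound 4 (0.24 log units; within the scatter).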

Compound 4, half-maximal inhibitory concentration: 23000 nM
Estimate against measurement, compound 4: 2.9-fold (0.46 log units) below; the measured number falls inside the stated range.
By their numbers in this assay, from the lowest: compound 3; then compounds 2 and 4 (each within the scatter of the next). At a limit, above all of these: compound 1.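

Among the aldehydes, bromo now stands apart at this aromatic carbon, and the change to methyl is as large as the earlier change from bromo to fluoro, in the opposite sense to what a small step would have given: a 5.0-fold higher number from compound 3 to compound 4 (0.70 log units; beyond the scatter) in this assay, whereas a 1.2-fold higher number from compound 2 to compound 4 (0.06 log units; within the scatter), so methyl and fluoro cannot be told apart here. For the compounds shown here, with 4-methylphenyl held constant, the formyl group can now be read as a single change on the shared core, and it gives the only large step: an at least 10-fold lower number from compound 1 to compound 4 (1.03 log units; beyond the scatter). That step has an open end, as compound 1 stands at a limit and not at a number: the limit of > 250000 nM in this assay, at which 1 of the 4 values shown sits.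

From the compounds shown here alone, whether chloro, iodo or methoxy at this carbon would group with compound 3 or with compounds 2 and 4 remains open, so two ring substituents matching in this assay do not yet define a trend. Also open, going by these compounds, is whether the formyl step holds with bromo or fluoro on the ring, and whether a carboxylic acid or a hydroxymethyl group in place of formyl would keep any of it.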